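Capping the hydroxyl of compound 1: working notes

The compounds below may be only part of what the source reports. "The series", "measured", "known", "first", "only" and "open" are said of these compounds alone.

For the measured compounds named here, in a functional assay on KB 3-1 cells (Homo sapiens) for antiproliferative activity, read by MTT assay (on this read-out lower numbers stand for stronger inhibition and higher numbers for weaker inhibition), compound 1 `O=C1C2C(O)CCCC2[C@H]2[C@@H]1CC(Br)C21OCCO1` gives 10 ug/mL, the only actual number so far. Compound 2 `C=CC[C@@H]1[C@@H]2[C@@H](CC(=O)[C@H]2CC=C)C[C@H]1O` gives only a limit of the assay, > 40 ug/mL. Compound 3 `C=CC[C@@H]1[C@H]2CC(=O)[C@H](CC=C)[C@H]2C[C@H]1O` also gives only a limit, > 40 ug/mL. No order can be read from these limits beyond what they state.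

Compound 4 `CC(C)(C)[Si](C)(C)OC1CCCC2C1C(=O)[C@H]1CC(Br)C3(OCCO3)[C@@H]21` retains the core of compound 1 and differs in one place: a group of 7 heavy atoms (6 carbon, 1 silicon; no ring) in place of a hydrogen atom, on an oxygen on a saturated carbon. Going by the values given here, no measured pair shows a change of this kind, so the expectation for this assay rests on compound 1 at 10 ug/mL alone. The expected step is a 1.5-fold higher number from compound 1 to compound 4 (0.18 log units; within the scatter), estimated to lie within the usual scatter, with a slight tilt towards weaker inhibition and a wide margin on its size. For compound 4 the estimated value is 15 ug/mL, with an expected range from 5 ug/mL to 40 ug/mL.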

Compound 4, half-maximal inhibitory concentration: > 40 ug/mL
Compound 4: no number, only a limit (the forecaster's own chance of this, stated with the estimate: 25%); middle value at least 2.6-fold (0.42 log units) away from the limit.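

For the compounds shown here, this is the only change at an oxygen on a saturated carbon: in this assay, a group of 7 heavy atoms (6 carbon, 1 silicon; no ring) in place of the hydrogen atom gives an at least 4.0-fold higher number from compound 1 to compound 4 (0.60 log units; beyond the scatter). Compound 4 gives only a limit of the assay, > 40 ug/mL, and not a number. Of the compounds compared at this position, only compound 1, with the free hydroxyl, gives a number, and the step has a lower bound but no measured size: the limit of > 40 ug/mL in this assay, at which 3 of the 4 values shown sit.

Going by these compounds, whether the step follows from losing the hydrogen atom or from the particular group that enters remains open. A methyl group or an acetyl group on the same oxygen would bear on that question, and either could sit at any point from the value of compound 1 to the limit.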